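The source may hold more compounds than are shown below. What is called first, only, known or untested is meant among the compounds shown, and "the series" means these compounds.

Compound 1 `CC(C)C(Cc1ncc[nH]1)c1ccc(-c2ccc3cccc(F)c3c2)[nH]c1=O` gives 0.106 h in an ADME assay on microsomes from liver (Homo sapiens) for metabolic stability; on this read-out lower numbers stand for a shorter-lived compound and higher numbers for a longer-lived compound. Compound 2 `CC(C)C(c1noc(=O)[nH]1)c1ccc(-c2ccc3cccc(F)c3c2)[nH]c1=O` gives > 3 h, which is a limit of this assay and not a number. Compound 3 `CC(C)C(Cc1nnn[nH]1)c1ccc(-c2ccc3cccc(F)c3c2)[nH]c1=O` gives > 3 h, also a limit rather than a number.

Compound 3 therefore stands at the upper edge of what this assay reports, the place where two of the three values sit (the limit of > 3 h in this assay, at which 2 of the 3 values shown sit). The measured steps that reach it are an at least 28-fold higher number from compound 1 to compound 3 (1.45 log units; beyond the scatter) and, beside it, an at least 28-fold higher number from compound 1 to compound 2 (1.45 log units; beyond the scatter); the remaining step, a step that the two limits leave unreadable from compound 2 to compound 3, gives no size.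

Compound 4 `CC(C)C(/C=C1/CCNC1=O)c1ccc(-c2ccc3cccc(F)c3c2)[nH]c1=O` differs from compound 3 as follows: a group of 7 heavy atoms (5 carbon, 1 nitrogen, 1 oxygen; one five-membered non-aromatic ring with 1 hetero atom) in place of a group of 6 heavy atoms (2 carbon, 4 nitrogen; one five-membered aromatic ring with 4 hetero atoms), on a saturated chain carbon bound to an aromatic carbon and a saturated chain carbon. Among the measured compounds shown here, both measured steps move from the imidazolyl group of compound 1 to an aromatic ring richer in hetero atoms; none moves from compound 3 toward a non-aromatic ring, so there is no measured step that bears directly on this change, and the large steps from compound 1 only show that the substituent on this chain carbon sets the half-life strongly. A downward step from the limit is expected for compound 4, an at least 2.5-fold lower number from compound 3 to compound 4 (0.39 log units; beyond the scatter), of uncertain size. Compound 4 is estimated at 1.2 h, with a range from 0.25 h to 3 h.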

Compound 4, half-life: 0.987 h
For compound 4 the middle estimate is 1.2-fold (0.08 log units) above the measured one, within the range that was stated.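

The non-aromatic ring of compound 4 gives a half-life that is measurable in this assay, which the aromatic rings richer in hetero atoms did not, with an at least 3.0-fold lower number from compound 3 to compound 4 (0.48 log units; beyond the scatter) and an at least 3.0-fold lower number from compound 2 to compound 4 (0.48 log units; beyond the scatter). Both of these steps start from a limit, so only their minimum size can be read: the limit of > 3 h in this assay, at which 2 of the 4 values shown sit. Compound 4 still gains on the imidazolyl group, with a 9.3-fold higher number from compound 1 to compound 4 (0.97 log units; beyond the scatter), so an aromatic ring is not needed on this saturated chain carbon for a number well above that of compound 1.

On these data alone, the step between compound 2 and compound 3 cannot be read, so the order of those two stays open. The compounds shown also leave open how a carboxylic acid or a simple open-chain amide in this place would compare.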